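The compounds below may be only part of what the source reports. "The series", "measured", "known", "first", "only" and "open" are said of these compounds alone.

Measured so far:
compound 1 `O=C(O)COc1ccncc1-c1ccc2ccccc2c1`: 16%
compound 2 `CCOC(=O)/C=C/c1ccncc1-c1ccc2cc[nH]c2c1`: 104%

Among the measured compounds shown here, in an assay on a protein complex for inhibition of CDK8/Cyclin C (Homo sapiens), with a stated time of 1 h, tested at 10 uM (a lower number here means less inhibition, a higher number more inhibition at the concentration tested (going by the name of the read-out)), compound 1 gives 16%, the lower of the two numbers so far; compound 2, with 104%, lies far higher, a gap well beyond the usual scatter. Compound 2 differs from compound 1 in more than one place, so no single step can be read from that pair.

Compound 3 `COC(=O)CCc1ccncc1-c1ccc2ccccc2c1` is not yet measured. It differs from compound 1 at one place: 2-(methoxycarbonyl)ethyl in place of carboxymethoxy on an aromatic carbon. The acid hydrogen-bond donor of compound 1 leaves and a methyl ester enters on a longer chain. Nothing measured in this series isolates such a change, so the direction of the step is open; a move beyond the scatter in either direction is possible, a modest rise being expected on the numbers at hand.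

For compound 3 the estimate in this assay is 40%, range 8% to 85%, an expected step of a number 24 percentage points higher from compound 1 to compound 3 (beyond the scatter).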

Compound 3, a percentage reported as inhibition, at one concentration (the size of the read-out at that concentration, not a potency): 98%
Compound 3: middle estimate off by 58 percentage points, on the low side; the whole stated range lies below it.
By their numbers in this assay, from the lowest: compound 1; then compounds 3 and 2 (each within the scatter of the next).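

In this assay, among the compounds shown here, 2-(methoxycarbonyl)ethyl in place of carboxymethoxy gives a number 82 percentage points higher from compound 1 to compound 3 (beyond the scatter), the first single-place step, and it shows that the read-out responds strongly to the group on this aromatic carbon, ortho to a large group and opposite the ring nitrogen. The leaving group carries a hydrogen-bond donor and the entering group none, while the chain and its atoms also differ, so the step bundles these changes and cannot be assigned to any one of them. No measurement at hand bears on the reason for the step.

A carboxylic acid on the same ethyl chain, or a methyl ester on the oxygen-linked chain, would separate the ester from the linker. From the compounds shown here alone, how an amide or a longer chain at this position behaves also remains open.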